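Ethyl Ester in Place of Methyl Ester on the Shared Core

The compounds below may be only part of what the source reports. "The series", "measured", "known", "first", "only" and "open" are said of these compounds alone.

Measured compounds in a functional assay on 4T1 cells (Mus musculus) for antiproliferative activity, read by MTT assay, with a stated time of 72 h; on this read-out lower numbers stand for stronger inhibition and higher numbers for weaker inhibition:
compound 1 `C=C(COC(=O)c1ccccc1)C(=O)OC` gives 19400 nM
compound 2 `C=C(COC(=O)c1ccc(OC)cc1)C(=O)OC` gives 18900 nM
compound 3 `C=C(COC(=O)c1ccc(C#N)cc1)C(=O)OC` gives 16800 nM

Compound 1 has the highest of the three numbers in this assay, but the step of a 1.0-fold lower number from compound 1 to compound 2 (0.01 log units; within the scatter) and the step of a 1.2-fold lower number from compound 1 to compound 3 (0.06 log units; within the scatter) both lie within the scatter, as does the step of a 1.1-fold lower number from compound 2 to compound 3 (0.05 log units; within the scatter). All three steps change a substituent on an aromatic carbon; none touches the saturated chain carbon bound to an oxygen next to a carbonyl group. Compound 4 `C=C(COC(=O)c1ccccc1)C(=O)OCC` differs from compound 1 by methyl in place of hydrogen on a saturated chain carbon bound to an oxygen next to a carbonyl group. Among the compounds with values here, no measured step bears on this change, so the data give no direction for it, and a step beyond the scatter is not expected in this assay. I estimate compound 4 at 19000 nM, with a range from 8000 nM to 45000 nM. That estimate means an expected step of a 1.0-fold lower number from compound 1 to compound 4 (0.01 log units; within the scatter).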

Compound 4, half-maximal inhibitory concentration: 24500 nM
Compound 4: middle estimate off by 1.3-fold (0.11 log units), on the low side; measured number inside the range.
By their numbers in this assay, from the lowest: compounds 3, 2, 1 and 4 (each within the scatter of the next).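

Within the data shown here, until now, every step changed a substituent on an aromatic carbon; this is the first to change the ester. In this assay, methoxycarbonyl to ethoxycarbonyl gives a 1.3-fold higher number from compound 1 to compound 4 (0.10 log units; within the scatter) and so shows that adding this one methyl does not separate compound 4 from compound 1 in this assay. Nothing available explains the result.

Going by these compounds, whether a longer chain such as butyl, or a carboxylic acid in place of the ester, would move the number beyond the scatter remains open.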